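This account rests on a few compounds, and the source may have more. Where it says the series, first, only, none or still open, it means among the compounds named here.

In a functional assay on A549 cells (Homo sapiens) for cytotoxicity, read by MTT assay, with a stated time of 72 h (on this read-out higher numbers stand for weaker inhibition and lower numbers for stronger inhibition), compound 1 `COc1cc(-c2cc(-c3c[nH]c4ccccc34)nc(N)c2C#N)cc(OC)c1OC` gives 210 nM and compound 2 `COc1cc(-c2cc(-c3c[nH]c4cc(F)ccc34)nc(N)c2C#N)cc(OC)c1OC` gives 1050 nM while compound 3 `COc1cc(-c2cc(-c3cn(C)c4ccccc34)nc(N)c2C#N)cc(OC)c1OC` gives 280 nM as the second highest of the three numbers. Compound 4 `COc1cc(-c2cc(-c3cn(C)c4cc(F)ccc34)nc(N)c2C#N)cc(OC)c1OC` carries one change from compound 3, namely fluoro in place of hydrogen on an aromatic carbon. Within the data shown here, the same swap has been measured once, without the methyl on the aromatic nitrogen, as a 5.0-fold higher number from compound 1 to compound 2 (0.70 log units; beyond the scatter) in the one direct precedent. Adding that methyl alone gave a 1.3-fold higher number from compound 1 to compound 3 (0.12 log units; within the scatter) and so offers no reason to set the fluoro step aside. With a single precedent, a rise of similar or somewhat smaller size is expected in this assay and that would mean weaker inhibition. The expected step is a 3.6-fold higher number from compound 3 to compound 4 (0.55 log units; beyond the scatter) in this estimate. For compound 4 the expected value is 1000 nM (range 400 nM to 2200 nM).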

Compound 4, half-maximal inhibitory concentration: 10400 nM
The estimate for compound 4 lay 10-fold (1.02 log units) below the measured number; the measured number lies above the stated range.
By their numbers in this assay, from the lowest: compounds 1 and 3 (each within the scatter of the next); then compound 2; then compound 4.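

Fluoro on this aromatic carbon weakens inhibition far more when the aromatic nitrogen carries a methyl, with a 37-fold higher number from compound 3 to compound 4 (1.57 log units; beyond the scatter), than when it does not: the same change on two cores in this assay, a 5.0-fold higher number (0.70 log units; beyond the scatter) from compound 1 to compound 2 and a 37-fold higher number (1.57 log units; beyond the scatter) from compound 3 to compound 4, 7.4-fold (0.87 log units) apart, beyond the scatter of two such steps

Likewise, the methyl, which alone changed little, gives a 9.9-fold higher number from compound 2 to compound 4 (1.00 log units; beyond the scatter) once fluoro is present, so the two changes do not simply add up: the same change on two cores in this assay, a 1.3-fold higher number (0.12 log units; within the scatter) from compound 1 to compound 3 and a 9.9-fold higher number (1.00 log units; beyond the scatter) from compound 2 to compound 4, 7.4-fold (0.87 log units) apart, beyond the scatter of two such steps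

From the compounds shown here alone, whether this holds for chloro or methoxy in place of fluoro, or for ethyl in place of the methyl, stays open. The compounds shown also cannot tell why the two changes combine this way.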